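Changing the sulfonyl aryl group and expected clearance

The compounds below may be only part of what the source reports. "The series", "measured", "known", "first", "only" and "open" are said of these compounds alone.

In an ADME assay on microsomes from liver (Homo sapiens) for metabolic stability, tested at 2.5 uM (on this read-out lower numbers stand for slow clearance and higher numbers for fast clearance), compound 3 `O=S(=O)(c1ccc(F)c(F)c1)c1cnc2cc(F)ccc2c1-c1cccc(F)c1` gives 0.6 mL/min, the lowest of the three numbers. Compound 2 `COc1cccc(-c2c(S(=O)(=O)c3cccc(C#N)c3)cnc3cc(F)ccc23)c1` gives 1.83 mL/min and compound 1 `COc1cccc(S(=O)(=O)c2cnc3cc(F)ccc3c2-c2cccc(F)c2)c1` gives 3.36 mL/min in this assay. For the measured compounds named here, only one measured step bears on the change to compound 4 `N#Cc1cccc(S(=O)(=O)c2cnc3cc(F)ccc3c2-c2cccc(F)c2)c1`: the move a 5.6-fold lower number from compound 1 to compound 3 (0.75 log units; beyond the scatter), also at the sulfonyl sulfur. Compound 4 differs from compound 3 by 3-cyanophenyl in place of 3,4-difluorophenyl on a sulfonyl sulfur. Compound 2 also carries a 3-cyanophenyl on its sulfonyl sulfur, but it differs from compound 4 in a second place, so only its value can be compared. Compound 4 is therefore expected to show a 2.2-fold higher number from compound 3 to compound 4 (0.34 log units; beyond the scatter) in this assay, a modest rise. Compound 4 is estimated at 1.3 mL/min, within 0.5 mL/min to 3 mL/min.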

Compound 4, intrinsic clearance in a liver preparation (reported as CLH), per the amount of preparation that the assay uses: 0.78 mL/min
Beside the measured number, compound 4's estimate is 1.7-fold (0.22 log units) above it; the measured number falls inside the stated range.
By their numbers in this assay, from the lowest: compounds 3 and 4 (each within the scatter of the next); then compounds 2 and 1 (each within the scatter of the next).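

At the sulfonyl sulfur, 3-cyanophenyl and 3,4-difluorophenyl cannot be told apart in this assay, where the change gives a 1.3-fold higher number from compound 3 to compound 4 (0.11 log units; within the scatter) and no ranking of the two follows. Cyano in place of methoxy on an aromatic carbon gives a 4.3-fold lower number from compound 1 to compound 4 (0.63 log units; beyond the scatter), and fluoro in place of methoxy on an aromatic carbon gives a 2.3-fold lower number from compound 2 to compound 4 (0.37 log units; beyond the scatter), so both listed replacements of methoxy lower the number. Nothing measured here explains these steps.

As far as these compounds go, whether a phenyl carrying an amine or a carboxylic acid on the sulfonyl sulfur would keep the number this low stays open.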